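Swapping a Side Chain on a Thromboxane Synthase Series

This account rests on a few compounds, and the source may have more. Where it says the series, first, only, none or still open, it means among the compounds named here.

Compound 1 `CC(C)n1nc(-c2cccnc2)c2ccccc2c1=O` carries an isopropyl group on an aromatic nitrogen of its core. In an assay on isolated protein (Oryctolagus cuniculus) with Thromboxane-A synthase (Homo sapiens) as the target, tested at 1 uM (on this read-out lower numbers stand for less inhibition and higher numbers for more inhibition at the one concentration tested (going by the name of the read-out)), compound 1 gives 87%. For the measured compounds named here, its only measured companion is compound 2 `CC(C)=CCn1nc(-c2cccnc2)c2ccccc2c1=O`, which in this assay gives 94%; the step of a number 7 percentage points higher from compound 1 to compound 2 (within the scatter) is one of the two numbers that lie within the scatter of each other, so although compound 1 sits at the lower end of the pair, the two cannot be told apart on this read-out.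

The compound now in question is compound 3 `COCCn1nc(-c2cccnc2)c2ccccc2c1=O`. Relative to compound 1 the change is 2-methoxyethyl in place of isopropyl on an aromatic nitrogen. Going by the values given here, the one measured step that bears on it, a number 7 percentage points higher from compound 1 to compound 2 (within the scatter), also replaced the isopropyl on that same aromatic nitrogen with another small chain and moved the number by no more than the scatter. On that basis the step of a number 2 percentage points lower from compound 1 to compound 3 (within the scatter) is expected to stay within the scatter as well, with no clear direction. Compound 3 is therefore estimated to give 85% in this assay, within a range from 70% to 95%.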

Compound 3, a percentage reported as inhibition, at one concentration (the size of the read-out at that concentration, not a potency): 55%
Compound 3: the middle estimate sits 30 percentage points above what was measured; the whole stated range lies above it.
By their numbers in this assay, from the lowest: compound 3; then compounds 1 and 2 (each within the scatter of the next).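

In this assay this position on the aromatic nitrogen turns out not to accept every small chain: 2-methoxyethyl in place of isopropyl gives a number 32 percentage points lower from compound 1 to compound 3 (beyond the scatter) and, seen against the other chain, methoxymethyl in place of 2-methylprop-1-en-1-yl on the saturated chain carbon bound to that nitrogen gives a number 39 percentage points lower from compound 2 to compound 3 (beyond the scatter) in the same read-out. The earlier step, a number 7 percentage points higher from compound 1 to compound 2 (within the scatter) on its own, suggested a forgiving position, but that holds only for the two chains made of carbon and not for the chain that carries an oxygen and a hydrogen-bond acceptor. Nothing in the data shown explains this drop in inhibition.

On these data alone, what stays open is whether the oxygen or simply the shape and length of the new chain matters, and a plain butyl chain made of carbon only would help to separate the two. A 2-hydroxyethyl or 2-aminoethyl chain would show whether other groups at the end of the chain are met in the same way as the methoxy end.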